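Compound 4 within the cytotoxicity series

A few compounds are considered here, and "the series" means these few. Any claim that something is new, unique, unknown or untested is made for them only; others in the source may bear on it.

Measured in an ADME assay on BHK-21 cells (Mesocricetus auratus) for cytotoxicity, read by MTT assay; on this read-out lower numbers stand for higher toxicity in this test and higher numbers for lower toxicity in this test:
- compound 1 `CC(=O)c1ccc2[nH]c(-c3ccccc3)nc2c1`: > 100000 nM, a limit
- compound 2 `COc1ccc(-c2nc3cc(C(C)=O)ccc3n2C2CCCCC2)cc1`: > 100000 nM, a limit
- compound 3 `CC(=O)c1ccc2c(c1)nc(-c1ccoc1)n2C1CCCCC1`: 77000 nM

Within the data shown here, compound 3 gives 77000 nM, the only number among the values shown. Everything else rests at the limit of > 100000 nM in this assay, at which 2 of the 3 values shown sit.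

Compound 4 `CC(=O)c1ccc2[nH]c(-c3ccoc3)nc2c1` arises from compound 3 through one change: hydrogen in place of cyclohexyl on an aromatic nitrogen.

Among the measured compounds shown here, the one measured step, an at least 1.2-fold lower number from compound 2 to compound 3 (0.11 log units; that floor lies within the scatter), concerns the group on an aromatic carbon rather than this nitrogen, so it bears on the change only indirectly. For the measured compounds named here, no measured step covers the nitrogen itself. Compound 1, which carries hydrogen there, shows > 100000 nM, and this is a limit.

No step beyond the scatter is therefore expected in this assay, and any small shift would more likely go towards a higher number. The estimated size is a 1.3-fold higher number from compound 3 to compound 4 (0.11 log units; within the scatter). A reading that gives only a limit is also quite possible. For compound 4 the estimate is 100000 nM, with an expected range of 55000 nM to 180000 nM.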

Compound 4, half-maximal cytotoxic concentration: 98000 nM
The estimate for compound 4 lay 1.0-fold (0.01 log units) above the measured number, within the range that was stated.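

In this assay, hydrogen in place of cyclohexyl on the aromatic nitrogen gives a 1.3-fold higher number from compound 3 to compound 4 (0.10 log units; within the scatter). Among these compounds, this is the first measured step at this nitrogen, and with furan-3-yl on the aromatic carbon, cyclohexyl and hydrogen read alike, so the number of compound 3 does not depend on the cyclohexyl group in this test. Furan-3-yl in place of phenyl on the aromatic carbon gives an at least 1.0-fold lower number from compound 1 to compound 4 (0.00 log units; that floor lies within the scatter). This step cannot be read further, because compound 1 stands at a limit: the limit of > 100000 nM in this assay, at which 2 of the 4 values shown sit.

From the compounds shown here alone, whether any group on this nitrogen can move the number beyond the scatter stays open, since only cyclohexyl and hydrogen are compared there. A methyl group, a longer chain ending in an amine or a carboxylic acid at this place would test that.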